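Swapping cyclohexyl for benzyl on an imidazole nitrogen

The source may report more compounds than this note shows. Statements on the series, on what has been measured and on what is new or still open speak of the compounds shown alone.

Measured compounds:
- compound 1 `c1ccc2c(-c3cn4ccnc4c(-c4ccc5ncn(C6CCCCC6)c5c4)n3)cccc2c1`: 25.2%
- compound 2 `c1ccc(Cn2cnc3ccc(-c4nc(-c5cccc6ccccc56)cn5ccnc45)cc32)cc1`: 27.1%
- compound 3 `c1cn2cc(-c3ccc4c(c3)ncn4C3CCCCC3)nc(-c3ccc4ncn(C5CCCCC5)c4c3)c2n1`: 15.9%

Of the compounds shown here, three have been tested in a functional assay on CAKI-1 cells (Homo sapiens) for inhibition, read by sulforhodamine B assay, with a stated time of 48 h, tested at 10 uM; on this read-out lower numbers stand for less inhibition and higher numbers for more inhibition at the one concentration tested (going by the name of the read-out). Compound 1 gives 25.2% in this assay, and compound 2 gives 27.1%. The two differ in one place, described as benzyl in place of cyclohexyl on an aromatic nitrogen; this change carries a step of a number 1.9 percentage points higher from compound 1 to compound 2 (within the scatter), which is within the scatter of the measurement, so compounds 1 and 2 cannot be told apart by this read-out.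

Compound 3 gives 15.9% in this assay. Its value is the lowest of the three, but it lies within the scatter of compound 1 and only beyond the scatter of compound 2. Compound 3 and compound 1 differ in more than one place; the difference between the two cores is not broken down here.

Compound 4 `c1ccc(Cn2cnc3ccc(-c4nc(-c5ccc6c(c5)ncn6C5CCCCC5)cn5ccnc45)cc32)cc1` has not yet been measured. It differs from compound 3 by benzyl in place of cyclohexyl on an aromatic nitrogen, the same change that separates compound 1 from compound 2. Because that earlier change gave a step of a number 1.9 percentage points higher from compound 1 to compound 2 (within the scatter), the step from compound 3 to compound 4 is expected to be similarly small, estimated as a number 2.1 percentage points higher from compound 3 to compound 4 (within the scatter). On this basis compound 4 is expected to give about 18% in this assay, with a likely range from 8% to 30%, resting on a single earlier example.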

Compound 4, a percentage reported as inhibition, at one concentration (the size of the read-out at that concentration, not a potency): 56.7%
Beside the measured number, compound 4's estimate is 38.7 percentage points below it, and the stated range ends below it.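

In this assay, benzyl in place of cyclohexyl on an aromatic nitrogen gives a number 40.8 percentage points higher from compound 3 to compound 4 (beyond the scatter), and this is not the size of effect the same swap has on the other core: the same change on two cores in this assay, a number 1.9 percentage points higher (within the scatter) from compound 1 to compound 2 and a number 40.8 percentage points higher (beyond the scatter) from compound 3 to compound 4, 38.9 percentage points apart, beyond the scatter of two such steps. The swap therefore cannot be treated in this series as a fixed increment that adds the same amount to any core, and a step read on one core is a poor guide to the step on another. These two pairs do not show why the cores respond so differently, nor which feature of the core matters, and each value is a single reading at one concentration, so they say nothing about potency.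

Compound 4 still carries one cyclohexyl, so the compounds shown leave open what a second benzyl in its place would do to the reading. They also leave open whether the large step belongs to benzyl in particular or would also appear with a different kind of group on that nitrogen, such as a longer chain ending in an amine or a carboxylic acid.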